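The source may hold more compounds than are shown below. What is called first, only, known or untested is meant among the compounds shown, and "the series" means these compounds.

Measured compounds:
Compound 1 `COc1cc(OC)cc(N2CCN(C(=O)c3onc(C)c3-c3ccccc3)CC2)c1` — 152 nM
Compound 2 `Cc1nc(-c2ccccc2)c(C(=O)N2CCN(c3ccc(Cl)c(Cl)c3)CC2)o1` — 124 nM
Compound 3 `CCc1nc(-c2ccccc2F)c(C(=O)N2CCN(c3cccc(Cl)c3)CC2)o1` — 139 nM

These three were tested in a functional assay on HL-60 cells (Homo sapiens) for inhibition, read by MTT assay, with a stated time of 72 h; a higher number here means a weaker inhibitor, a lower number a stronger inhibitor. Compound 2 has the lowest of the three numbers, but its gaps to compound 3 and to compound 1 are both within the usual scatter of repeated measurements, so nothing separates them with confidence. Compound 4 `Cc1nc(-c2ccccc2)c(C(=O)N2CCN(c3ccc(C(F)(F)F)cc3)CC2)o1` has not yet been measured. It differs from compound 2 in one place: 4-(trifluoromethyl)phenyl in place of 3,4-dichlorophenyl on an amine nitrogen in a ring. Among the compounds with values here, no pair of measured compounds differs in only one place, so no measured step can guide the expectation directly. Because compound 2 gives 124 nM while compound 3 gives 139 nM and compound 1 gives 152 nM with all three within the scatter of one another, the aryl group on the ring nitrogen appears to matter little here, and the step from compound 2 to compound 4 is expected to be a 1.4-fold higher number from compound 2 to compound 4 (0.14 log units; within the scatter), a small change not clearly beyond the scatter. Compound 4 is estimated at 170 nM, between 70 nM and 400 nM.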

Compound 4, half-maximal inhibitory concentration: > 1000 nM
Compound 4: a limit, no number (the forecaster's own chance of this, stated with the estimate: 3%); middle value at least 5.8-fold (0.76 log units) away from the limit.
By their numbers in this assay, from the lowest: compounds 2, 3 and 1 (each within the scatter of the next). At a limit, above all of these: compound 4.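

Compound 4 gives > 1000 nM in this assay and this is a limit, not a number. Putting 4-(trifluoromethyl)phenyl in place of 3,4-dichlorophenyl on the amine nitrogen in the ring gives an at least 8.0-fold higher number from compound 2 to compound 4 (0.90 log units; beyond the scatter) and so counts as a real loss of inhibition. Within the data shown here, this position is therefore not indifferent to its aryl group, something the earlier compounds, which differ from one another in several places, could not show. How a plain phenyl or a phenyl bearing a nitrile would read on that nitrogen remains open, and so does the true size of the step: the limit of > 1000 nM in this assay, at which 1 of the 4 values shown sits.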